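A few compounds are considered here, and "the series" means these few. Any claim that something is new, unique, unknown or untested is made for them only; others in the source may bear on it.

Measured compounds:
- Compound 1, `O=C(Nc1ccccc1C(F)(F)F)c1ccc2ccccc2n1`, in a functional assay on NCI-H23 cells (Homo sapiens) for cytotoxicity, read by sulforhodamine B assay, with a stated time of 72 h; a lower number here means a stronger inhibitor of growth, a higher number a weaker inhibitor of growth: > 90000 nM, a limit of the assay rather than a number
- Compound 2, `O=C(Nc1cc(C(F)(F)F)cc(C(F)(F)F)c1)C1CCc2ccccc2N1C(=O)c1cccc(Cl)c1`: 420 nM
- Compound 3, `O=C(Nc1cc(C(F)(F)F)cc(C(F)(F)F)c1)C1CCc2ccccc2N1C(=O)c1ccccc1Cl`: 2080 nM

Among the measured compounds shown here, compound 1 stands at the weak end of what has been measured: its value is only a limit, and the limit of > 90000 nM in this assay, at which 1 of the 3 values shown sits, shows that it is the one compound whose growth inhibition could not be pinned to a number. Compounds 2 and 3 share a different core and differ from each other only in the position of a chlorine on a phenyl attached to a carbonyl carbon; that change gave a 5.0-fold higher number from compound 2 to compound 3 (0.69 log units; beyond the scatter).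

Compound 4, `O=C(Nc1ccccc1O)c1ccc2ccccc2n1`, differs from compound 1 in one place: hydroxy in place of trifluoromethyl on an aromatic carbon.

For the measured compounds named here, no measured step touches this change, and the one step known, from compound 2 to compound 3, concerns another core and another kind of substituent, so it gives no guide to the size or direction of what a hydroxy in place of a trifluoromethyl might do here. With compound 1 sitting at the limit, the prior expectation is that compound 4 also inhibits growth weakly in this assay, and the step of an at least 1.5-fold lower number from compound 1 to compound 4 (0.17 log units; that floor lies within the scatter) is expected to be small or unresolved. Compound 4 is therefore estimated at 60000 nM, within a range from 10000 nM to 150000 nM.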

Compound 4, concentration for 50% growth inhibition: 87500 nM
For compound 4 the middle estimate is 1.5-fold (0.16 log units) below the measured one; the range from low to high includes it.
By their numbers in this assay, from the lowest: compound 2; then compound 3; then compound 4. At a limit, above all of these: compound 1.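

In this assay compound 1 gives > 90000 nM, which is a limit of the assay and not a number. With hydroxy in place of trifluoromethyl on this aromatic carbon, ortho to a large group, compound 4 gives 87500 nM, so this change on the shared core yields a value that can be stated as a number, which the trifluoromethyl compound did not provide. The true size of the change remains unknown, and the result can be read only as a floor, an at least 1.0-fold lower number from compound 1 to compound 4 (0.01 log units; that floor lies within the scatter), because the starting value is a limit: the limit of > 90000 nM in this assay, at which 1 of the 4 values shown sits.

Going by these compounds, it remains open whether another group on this same aromatic carbon, such as an amine, a methoxy group or a carboxylic acid, would give a clearly lower number on the core of compound 1. On these data alone, it is also open whether hydroxy in place of trifluoromethyl would have a similar outcome on another carbon of that ring, or on the different core shared by compound 2 and compound 3.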